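Longer ester chains, stronger effect on lung cancer cells

A few compounds are considered here, and "the series" means these few. Any claim that something is new, unique, unknown or untested is made for them only; others in the source may bear on it.

The measured compounds:
compound 1, `CCCCCCOC(=O)CCC(=O)N1CCN(CCCOc2cc3c(Nc4ccc(F)c(Cl)c4)ncnc3cc2OC)CC1`, gives 42.9%
compound 2, `CCCCCCCOC(=O)CCC(=O)N1CCN(CCCOc2cc3c(Nc4ccc(F)c(Cl)c4)ncnc3cc2OC)CC1`, gives 27.2%
compound 3, `CCCCCCCCCOC(=O)CCC(=O)N1CCN(CCCOc2cc3c(Nc4ccc(F)c(Cl)c4)ncnc3cc2OC)CC1`, gives 7.8%

All three share one core and differ only in the length of the ester chain; the numbers come from a functional assay on A549 cells (Homo sapiens) for cytotoxicity, read by MTT assay, with a stated time of 24 h, tested at 80 uM; a lower number here means a stronger effect, a higher number a weaker effect of the compound at the concentration tested. Compound 2 differs from compound 1 by methyl in place of hydrogen on a saturated chain carbon, six bonds along the chain from an oxygen next to a carbonyl group, with a step of a number 15.7 percentage points lower from compound 1 to compound 2 (beyond the scatter). Compound 3 differs from compound 1 by propyl in place of hydrogen on a saturated chain carbon, six bonds along the chain from an oxygen next to a carbonyl group, a step of a number 35.1 percentage points lower from compound 1 to compound 3 (beyond the scatter), and the remaining step is a number 19.4 percentage points lower from compound 2 to compound 3 (beyond the scatter). Compound 4, `CCCCCCCCCCOC(=O)CCC(=O)N1CCN(CCCOc2cc3c(Nc4ccc(F)c(Cl)c4)ncnc3cc2OC)CC1`, has not been measured yet. It differs from compound 3 by methyl in place of hydrogen on a saturated chain carbon, nine bonds along the chain from an oxygen next to a carbonyl group, the same kind of change as from compound 1 to compound 2, but the place is nine bonds rather than six bonds along the chain from an oxygen next to a carbonyl group. Because a number 15.7 percentage points lower from compound 1 to compound 2 (beyond the scatter) and a number 19.4 percentage points lower from compound 2 to compound 3 (beyond the scatter) both point downward, compound 4 is expected to give about 4%, most likely between 0% and 14%. This estimate means a step of a number 3.8 percentage points lower from compound 3 to compound 4 (within the scatter), smaller than the earlier ones since compound 3 already stands at 7.8% and the scale cannot fall much further.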

Compound 4, a percentage reported as activity, at one concentration (the size of the read-out at that concentration, not a potency): 2%
Compound 4: the middle estimate sits 2 percentage points above what was measured; the measured number falls inside the stated range.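

In this assay, adding one methyl at the end of the chain gives a number 5.8 percentage points lower from compound 3 to compound 4 (within the scatter), and this single-methyl change carries over from the shorter chain to the longer one within what the measurements can resolve: the same change on two cores in this assay, a number 15.7 percentage points lower (beyond the scatter) from compound 1 to compound 2 and a number 5.8 percentage points lower (within the scatter) from compound 3 to compound 4, 9.9 percentage points apart, within the scatter of two such steps Longer additions, propyl with a number 25.2 percentage points lower from compound 2 to compound 4 (beyond the scatter) and butyl with a number 40.9 percentage points lower from compound 1 to compound 4 (beyond the scatter), also agree with the earlier step of the same kind: the same change on two cores in this assay, a number 35.1 percentage points lower (beyond the scatter) from compound 1 to compound 3 and a number 25.2 percentage points lower (beyond the scatter) from compound 2 to compound 4, 9.9 percentage points apart, within the scatter of two such steps This does not prove that the steps are equal in size, only that no difference can be seen, and it does not rank compound 3 and compound 4 against each other; moreover, every comparison stays within this one series, where only the ester chain varies.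

The compounds shown leave open what a longer chain than that of compound 4, a branched chain or a carboxylic acid in place of the ester would give. They also leave open whether the chain-length trend would hold at other concentrations or in other cells.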